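The compounds below may be only part of what the source reports. "The series", "measured", "known", "first", "only" and "open" are said of these compounds alone.

Measured compounds:
compound 1, `NC(=O)c1cc(Cl)c2c(Cl)c(C#CCN3CCCC3=O)n([C@H]3CCCNC3)c2n1`: 178 nM
compound 2, `CC1(CC#Cc2c(Cl)c3c(Cl)cc(C(N)=O)nc3n2[C@H]2CCCNC2)COC1`: 289 nM

Within the data shown here, in a functional assay on KG-1 cells (Homo sapiens) for antiproliferative activity (a lower number here means that less compound is needed, a higher number that more compound is needed for the effect), compound 2 gives 289 nM, and compound 1 gives 178 nM; the one known step, a 1.6-fold higher number from compound 1 to compound 2 (0.21 log units; within the scatter), lies within the scatter, so the two compounds cannot be told apart on these numbers. Compound 3, `COCC(C)(C)C#Cc1c(Cl)c2c(Cl)cc(C(N)=O)nc2n1[C@H]1CCCNC1`, has not been measured. Compared with compound 2 it shows (1-(methoxymethyl)-1-methylethyl in place of (3-methyloxetan-3-yl)methyl on a triple-bonded carbon). Among the measured compounds shown here, the only measured step, a 1.6-fold higher number from compound 1 to compound 2 (0.21 log units; within the scatter), concerns a different exchange at the far end of the same triple-bonded chain and changed little, which suggests that the group at that end can be varied without a large effect; no measured step covers the ring-opening itself. The expectation for compound 3 is therefore a step of a 1.0-fold higher number from compound 2 to compound 3 (0.02 log units; within the scatter) from compound 2, not beyond the scatter, giving an estimated 300 nM with a range from 150 nM to 650 nM.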

Compound 3, half-maximal effective concentration: 219 nM
Compound 3: middle estimate off by 1.4-fold (0.14 log units), on the high side; low and high end bracket the measured number.
By their numbers in this assay, from the lowest: compounds 1, 3 and 2 (each within the scatter of the next).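

In this assay, replacing the ring of the (3-methyloxetan-3-yl)methyl group with the open-chain 1-(methoxymethyl)-1-methylethyl group keeps the count of heavy atoms and the single oxygen, and the result is a 1.3-fold lower number from compound 2 to compound 3 (0.12 log units; within the scatter). Exchanging the (2-oxopyrrolidin-1-yl)methyl group for the same open-chain group gives a 1.2-fold higher number from compound 1 to compound 3 (0.09 log units; within the scatter), so all three groups on this triple-bonded carbon lie within the scatter of one another, and among these compounds, a ring in this group is not required for a number in this range. No measurements are available that would explain this result.

All three groups contain oxygen, so the compounds shown do not tell how a plain hydrocarbon chain would behave at this place. On these data alone, an amine or a carboxylic acid there also remains open.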